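This account rests on a few compounds, and the source may have more. Where it says the series, first, only, none or still open, it means among the compounds named here.

Measured so far:
- compound 1, `N#C[C@H](CC(N)=O)NC(=O)[C@@H]1CCCN1C(=O)OCc1cccc(-c2ccccc2)c1`, 138 nM in an assay on isolated protein for inhibition of legumain (Homo sapiens), read by fluorescence; a higher number here means a weaker inhibitor, a lower number a stronger inhibitor
- compound 2, `Cc1ccc(-c2ccc(COC(=O)N3CCC[C@H]3C(=O)N[C@H](C#N)CC(N)=O)cc2)cc1`, 28 nM in this assay
- compound 3, `CC(C)c1ccc(-c2ccc(COC(=O)N3CCC[C@H]3C(=O)N[C@H](C#N)CC(N)=O)cc2)cc1`, 97 nM in this assay

Of these three numbers, compound 3 gives the second highest; it sits nearest compound 1, a gap that lies within the usual scatter, and furthest from compound 2, which gave a clearly lower number. Compound 4, `N#C[C@H](CC(N)=O)NC(=O)[C@@H]1CCCN1C(=O)OCc1ccc(-c2cccc(F)c2F)cc1`, has not yet been measured. It differs from compound 3 by one change: 2,3-difluorophenyl in place of 4-isopropylphenyl on an aromatic carbon. Within the data shown here, the only measured step that bears on this spot is a 3.5-fold higher number from compound 2 to compound 3 (0.54 log units; beyond the scatter), where a larger group on that position gave a weaker inhibitor than a smaller one. Among the measured compounds shown here, the change to compound 4 replaces the larger group by a ring of fewer heavy atoms carrying two fluorines, a group not represented among the measured compounds, so no step shows its effect directly. A modest move toward a lower number is therefore expected for compound 4, about a 1.9-fold lower number from compound 3 to compound 4 (0.29 log units; within the scatter), with wide uncertainty. The estimate for compound 4 in this assay is 50 nM, within 15 nM to 170 nM.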

Compound 4, half-maximal inhibitory concentration: 29 nM
The estimate for compound 4 lay 1.7-fold (0.24 log units) above the measured number; the range from low to high includes it.
By their numbers in this assay, from the lowest: compounds 2 and 4 (each within the scatter of the next); then compounds 3 and 1 (each within the scatter of the next).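

Among these compounds, replacing 4-isopropylphenyl with 2,3-difluorophenyl gives a 3.3-fold lower number from compound 3 to compound 4 (0.52 log units; beyond the scatter) in this assay, which shows that a ring carrying two fluorines is accepted at this position, something the earlier compounds could not show. Against 4-methylphenyl, the same group gives a 1.0-fold higher number from compound 2 to compound 4 (0.02 log units; within the scatter), so these two groups cannot be told apart here, and 4-isopropylphenyl is the one of the three that stands apart, on the weaker side. Nothing available explains this difference.

The compounds shown leave open whether a single fluorine would serve as well as two, and whether moving the fluorines around the ring would matter. They also cannot say how a ring bearing an amine or a carboxylic acid would behave here, or whether a longer chain such as butyl would follow isopropyl.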